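The compounds below may be only part of what the source reports. "The series", "measured", "known", "first", "only" and "open" are said of these compounds alone.

Compound 1, `C/C(=C\c1cc(-c2ccc(C)cc2)co1)C(N)=O`: > 50000 nM
Compound 2, `C/C(=C\c1cc(-c2ccc(F)cc2)co1)C(N)=O`: 14900 nM
Compound 3, `C/C(=C\c1cc(-c2ccc(C)cc2)cs1)C(N)=O`: > 50000 nM

Compound 1 `C/C(=C\c1cc(-c2ccc(C)cc2)co1)C(N)=O` in a functional assay on A549 cells (Homo sapiens) for cytotoxicity, read by CCK-8 assay, with a stated time of 24 h (on this read-out lower numbers stand for stronger inhibition and higher numbers for weaker inhibition), gives only a limit of the assay, > 50000 nM. Compound 2 `C/C(=C\c1cc(-c2ccc(F)cc2)co1)C(N)=O` in this assay gives 14900 nM. The change between them is fluoro in place of methyl on an aromatic carbon and it gave an at least 3.3-fold lower number from compound 1 to compound 2 (0.52 log units; beyond the scatter); the step is read against (the limit of > 50000 nM in this assay, at which 2 of the 3 values shown sit). Compound 3 `C/C(=C\c1cc(-c2ccc(C)cc2)cs1)C(N)=O` in this assay also gives only a limit, > 50000 nM. The difference between the core of compound 3 and the core of compound 1 is not broken down here. Compound 4 `C/C(=C\c1cc(-c2ccc(F)cc2)cs1)C(N)=O` has not yet been measured in this assay. It differs from compound 3 by fluoro in place of methyl on an aromatic carbon, which is the same change as that from compound 1 to compound 2, made on the core of compound 3. Resting on the step from compound 1 to compound 2, an at least 3.3-fold lower number from compound 1 to compound 2 (0.52 log units; beyond the scatter), and on the limit that compound 3 gave, the expected step to compound 4 is an at least 2.5-fold lower number from compound 3 to compound 4 (0.39 log units; beyond the scatter). Compound 4 is estimated at 20000 nM, between 8000 nM and 60000 nM, in this assay.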

Compound 4, half-maximal inhibitory concentration: > 50000 nM
Compound 4: only a limit was reported; the forecaster's own chance of this, stated with the estimate: 35%; at least 2.5-fold (0.39 log units) between middle value and limit.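

In this assay, going by these compounds alone, compound 3 and compound 4 both give only a limit, so no step between them can be read. The reading stands at: the limit of > 50000 nM in this assay, at which 3 of the 4 values shown sit.

The compounds shown leave open whether fluoro in place of methyl lowers the number on the core of compound 3, as it did from compound 1 to compound 2.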